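A benzyl swap on a sulfonyl sulfur

A few compounds are considered here, and "the series" means these few. Any claim that something is new, unique, unknown or untested is made for them only; others in the source may bear on it.

Measured in a functional assay for inhibition, with Homo sapiens as the target; a lower number here means a stronger inhibitor, a higher number a weaker inhibitor:
- compound 1 `CCCCCS(=O)(=O)N[C@@H](CNC(=O)c1ccc2c(c1)C(=O)N(CCC1CCNCC1)C2)C(=O)O`: 9 nM
- compound 2 `CCCCCC(=O)N[C@@H](CNC(=O)c1ccc2c(c1)C(=O)N(CCC1CCNCC1)C2)C(=O)O`: 13 nM
- compound 3 `O=C(NC[C@H](NS(=O)(=O)c1cccnc1)C(=O)O)c1ccc2c(c1)C(=O)N(CCC1CCNCC1)C2`: 15 nM

In this assay compound 3 gives 15 nM, a value that the data do not set apart from the other two. The measured steps show this: a 1.7-fold higher number from compound 1 to compound 3 (0.22 log units; within the scatter), and a 1.2-fold higher number from compound 2 to compound 3 (0.06 log units; within the scatter).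

Compound 4 `O=C(NC[C@H](NS(=O)(=O)Cc1ccccc1)C(=O)O)c1ccc2c(c1)C(=O)N(CCC1CCNCC1)C2` has not yet been measured. It keeps the rest of compound 3 and has benzyl in place of pyridin-3-yl on a sulfonyl sulfur.

Among the measured compounds shown here, no measured pair makes this exact swap, so the evidence is indirect. Putting pyridin-3-yl in place of pentyl on a sulfonyl sulfur gave a 1.7-fold higher number from compound 1 to compound 3 (0.22 log units; within the scatter). Putting pentylcarbonyl in place of pentylsulfonyl on an amine nitrogen gave a 1.4-fold higher number from compound 1 to compound 2 (0.16 log units; within the scatter). For the measured compounds named here, neither step leaves the scatter, and no measured compound goes against this small spread. Three compounds are a thin basis, however, and none of them carries benzyl.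

No change beyond the scatter is expected in this assay, and no direction can be favoured. The estimated step is a 1.1-fold lower number from compound 3 to compound 4 (0.03 log units; within the scatter). For compound 4 the estimated value is 14 nM, with an expected range of 6 nM to 35 nM.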

Compound 4, half-maximal inhibitory concentration: 4 nM
Compound 4: the middle estimate sits 3.5-fold (0.54 log units) above what was measured, and the stated range ends above it.
By their numbers in this assay, from the lowest: compound 4; then compounds 1, 2 and 3 (each within the scatter of the next).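

Among the first three compounds in this assay, no swap on the sulfonyl sulfur or the amine nitrogen left the scatter, so nothing showed that the group at this position mattered. Benzyl in place of pyridin-3-yl does leave it (a 3.8-fold lower number from compound 3 to compound 4 (0.57 log units; beyond the scatter)), so the group on the sulfonyl sulfur can shift the inhibitory concentration, even though the ring that leaves and the ring that enters are both six-membered and aromatic. Compound 4 also stands apart from the other two compounds (a 3.3-fold lower number from compound 2 to compound 4 (0.51 log units; beyond the scatter); a 2.3-fold lower number from compound 1 to compound 4 (0.35 log units; beyond the scatter)), the second of these steps being phenyl in place of butyl on the saturated chain carbon bound to the sulfonyl sulfur, and nothing available explains why benzyl gives the lowest number.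

A 2-phenylethyl group on the sulfonyl sulfur, or a benzyl group whose ring carries a chlorine or a methoxy group, would show how far this gain extends. Among the compounds shown here, a phenylacetyl group on the amine nitrogen would show whether the gain needs the sulfonyl link at all, since the only carbonyl example here, compound 2, carries a pentyl chain.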